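The source may report more compounds than this note shows. Statements on the series, on what has been measured and on what is new or still open speak of the compounds shown alone.

Compound 1 `C/C(=N\NC(=S)Nc1cccc(I)c1)c1ccccn1` is assessed in a functional assay on T98G cells (Homo sapiens) for cytotoxicity, read by MTT assay, with a stated time of 48 h (on this read-out lower numbers stand for stronger inhibition and higher numbers for weaker inhibition), where compound 1 gives 61 nM. Among the three measured compounds this places compound 1 second highest. Its nearest neighbour is compound 2 `C/C(=N\NC(=S)Nc1cccc([N+](=O)[O-])c1)c1ccccn1`, which in this assay gives 140 nM; the step of a 2.3-fold higher number from compound 1 to compound 2 (0.36 log units; beyond the scatter) is modest. Compound 3 `C/C(=N/NC(=S)Nc1ccccc1Cl)c1ccccn1` stands furthest away, giving 1.1 nM in this assay, a far lower number than compound 1 shows.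

The step now taken leads to compound 4 `C/C(=N/NC(=S)Nc1cccc(I)c1)c1ccccn1`. Against compound 1 the difference is the two compounds have the same atoms and bonds and differ only in configuration as drawn: 1 of 1 stereo elements differ; a double bond is drawn E in compound 1 and Z in compound 4. Among the measured compounds shown here, no measured step bears on a change of drawn configuration alone; the only step available, from compound 1 to compound 2, concerns a substituent and not geometry. Compound 3 is drawn in the other configuration and gives a much lower number, but it also carries a different substituent, so no conclusion follows. Compound 4 is therefore expected to show a 1.4-fold lower number from compound 1 to compound 4 (0.13 log units; within the scatter), a change not beyond the scatter, giving an estimated 45 nM within 12 nM to 180 nM.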

Compound 4, half-maximal inhibitory concentration: 61 nM
For compound 4 the middle estimate is 1.4-fold (0.13 log units) below the measured one; the range from low to high includes it.
By their numbers in this assay, from the lowest: compound 3; then compounds 1 and 4 (each within the scatter of the next); then compound 2.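

In this assay, turning the double bond from E to Z with the iodo group held fixed gives no change at the digits printed from compound 1 to compound 4 (within the scatter). The earlier compounds shown here could not isolate geometry, and this pair does: the fact that compounds 1 and 4 differ only in the configuration as drawn. For this iodo compound, drawn configuration alone therefore leaves the number unmoved.

From the compounds shown here alone, whether that also holds for the nitro compound, compound 2, stays open, as does what sets compound 3, at 1.1 nM, so far apart. Going by these compounds, what an amine or a methoxy group in place of the iodo group would give also remains open.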